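Exchanging a Basic Chain End for a Hydroxy Group

The compounds below may be only part of what the source reports. "The series", "measured", "known", "first", "only" and "open" are said of these compounds alone.

Measured so far:
compound 1 `Cc1cc2ccccc2n1CCNC(=O)/C=C/c1ccc(OCCCN(C)C)cc1` — 306000 nM
compound 2 `COc1cc(/C=C/C(=O)NCCn2c(C)cc3ccccc32)cc(OC)c1OCCO` — 66000 nM

In a physicochemical assay for solubility, read by nephelometry, in phosphate buffer, at pH 7.4 (a lower number here means a less soluble compound, a higher number a more soluble compound), compound 1 holds the higher of the two numbers, and compound 2 sits well beyond the scatter with its lower value. Compound 3 `Cc1cc2ccccc2n1CCNC(=O)/C=C/c1ccc(OCCO)cc1` has not yet been measured. It differs from compound 1 in one place: hydroxy in place of (dimethylamino)methyl on a saturated chain carbon, two bonds along the chain from an oxygen on an aromatic ring. Within the data shown here, with no measured pair to anchor the size of this change, compound 3 is expected to fall, in this assay, by about a 6.1-fold lower number from compound 1 to compound 3 (0.79 log units; beyond the scatter), because compound 2, which also carries a hydroxy-terminated chain, gives 66000 nM. The estimate for compound 3 is 50000 nM, within 15000 nM to 150000 nM.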

Compound 3, solubility: 68000 nM
Compound 3: middle estimate off by 1.4-fold (0.13 log units), on the low side; low and high end bracket the measured number.
By their numbers in this assay, from the lowest: compounds 2 and 3 (each within the scatter of the next); then compound 1.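

In this assay, among these compounds, the exchange of (dimethylamino)methyl for hydroxy on this saturated chain carbon gives a 4.5-fold lower number from compound 1 to compound 3 (0.65 log units; beyond the scatter) and is the first measured size for this change on the shared core. The step is modest but beyond the scatter, so at this position the two chain ends are not equivalent in this read-out. Nothing measured here gives a reason for the step. On these data alone, whether a carboxylic acid or a morpholine at the chain end, or a longer chain ending in hydroxy, would land nearer compound 1 or compound 3 remains open.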